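This account rests on a few compounds, and the source may have more. Where it says the series, first, only, none or still open, it means among the compounds named here.

Compound 1 `NC(=O)c1cc(Cl)ccc1NC(=O)COc1ccccc1`: 1410 nM
Compound 2 `NC(=O)c1cc(I)ccc1NC(=O)COc1ccccc1`: 1020 nM

In a functional assay on A498 cells (Homo sapiens) for inhibition (on this read-out lower numbers stand for stronger inhibition of growth and higher numbers for weaker inhibition of growth), compound 2 gives 1020 nM, and compound 1, at 1410 nM, lies within the scatter of it, so the two cannot be ranked. Compound 3 `COc1ccc(NC(=O)COc2ccccc2)c(C(N)=O)c1` carries methoxy in place of iodo on an aromatic carbon. Going by the values given here, only one measured step bears on this, a 1.4-fold lower number from compound 1 to compound 2 (0.14 log units; within the scatter), with iodo in place of chloro. It involves no methoxy, so it is weak guidance, and no change beyond the scatter is expected in this assay. The expected step, with a slight lean to a higher number, is a 1.5-fold higher number from compound 2 to compound 3 (0.17 log units; within the scatter). For compound 3 the estimated value is 1500 nM, with an expected range of 500 nM to 4500 nM.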

Compound 3, concentration for 50% growth inhibition: 304 nM
Compound 3: middle estimate off by 4.9-fold (0.69 log units), on the high side; measured number outside the range, below it.
By their numbers in this assay, from the lowest: compound 3; then compounds 2 and 1 (each within the scatter of the next).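

At this position, para to a large group, swapping chloro for iodo moved the number only within the scatter, but methoxy moves it beyond the scatter. In this assay, replacing iodo with methoxy gives a 3.4-fold lower number from compound 2 to compound 3 (0.53 log units; beyond the scatter), and replacing chloro with methoxy gives a 4.6-fold lower number from compound 1 to compound 3 (0.67 log units; beyond the scatter), so this carbon is not indifferent to what it carries. Nothing at hand explains why the number falls. The compounds shown leave open whether the lower number belongs to methoxy alone or extends to other groups here, such as a hydroxyl, an ethoxy chain or an amine.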